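The source may hold more compounds than are shown below. What is called first, only, known or untested is meant among the compounds shown, and "the series" means these compounds.

Compound 1 `COc1ccc(OC)c(/C=N/NC(=O)Nc2ccc(Oc3ccnc(-c4nncn4CCN(C)C)c3)c(F)c2)c1` was tested in a functional assay on A549 cells (Homo sapiens) for cytotoxicity, read by MTT assay, with a stated time of 72 h (a higher number here means a weaker inhibitor, a lower number a stronger inhibitor), where compound 1 gives 1950 nM, the highest of the three numbers recorded so far. Compound 2 `CN(C)CCn1cnnc1-c1cc(Oc2ccc(NC(=O)N/N=C/c3cccc(Cl)c3Cl)cc2F)ccn1` gives 1090 nM and compound 3 `CN(C)CCn1cnnc1-c1cc(Oc2ccc(NC(=O)N/N=C/c3c(O)ccc4ccccc34)cc2F)ccn1` gives 880 nM. Compound 4 `CN(C)CCn1cnnc1-c1cc(Oc2ccc(NC(=O)N/N=C/c3ccc(F)cc3F)cc2F)ccn1` has not yet been measured. It differs from compound 1 in one place: 2,4-difluorophenyl in place of 2,5-dimethoxyphenyl on a carbon with a double bond to nitrogen. For the measured compounds named here, two measured steps bear on a swap at this same position: a 1.8-fold lower number from compound 1 to compound 2 (0.25 log units; within the scatter) and a 2.2-fold lower number from compound 1 to compound 3 (0.35 log units; beyond the scatter). Both replacements of the 2,5-dimethoxyphenyl group gave lower numbers, one within the scatter and one modestly beyond it. A similar small lowering, or none beyond the scatter, is therefore expected for compound 4, and the expected step is a 1.5-fold lower number from compound 1 to compound 4 (0.18 log units; within the scatter). Compound 4 is estimated at 1300 nM, with a range from 600 nM to 2800 nM.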

Compound 4, half-maximal inhibitory concentration: 1870 nM
Compound 4: the middle estimate sits 1.4-fold (0.16 log units) below what was measured, and the stated range covers the measured number.
By their numbers in this assay, from the lowest: compounds 3, 2, 4 and 1 (each within the scatter of the next, the first and the last beyond it).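

At this position, 2,4-difluorophenyl cannot be told apart from 2,5-dimethoxyphenyl (a 1.0-fold lower number from compound 1 to compound 4 (0.02 log units; within the scatter)), although the entering group counts 0 hydrogen-bond acceptors and the leaving group 2. It also stays within the scatter of 2,3-dichlorophenyl (a 1.7-fold higher number from compound 2 to compound 4 (0.23 log units; within the scatter)), and only 2-hydroxynaphthalen-1-yl stands modestly apart from it (a 2.1-fold higher number from compound 3 to compound 4 (0.33 log units; beyond the scatter)). No measurement given here explains these results. The compounds shown leave open whether an amine or a carboxylic acid on this ring would move the number further than these aryl groups do.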